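Methoxy to Hydroxy on a Shared Pyrazole Core

The source may hold more compounds than are shown below. What is called first, only, known or untested is meant among the compounds shown, and "the series" means these compounds.

Of the compounds shown here, two sharing one core have been measured in a functional assay on BT-549 cells (Homo sapiens) for cytotoxicity, read by sulforhodamine B assay, with a stated time of 48 h, tested at 1 uM; a higher number here means a weaker effect of the compound at the concentration tested, a lower number a stronger effect. Compound 1 `Cc1cc(O)cc(-c2nn(CC#N)cc2-c2ccnc(-c3ccc(Oc4ccccc4)cc3)c2)c1` gives 4%, while compound 2 `COc1cc(C)cc(-c2nn(CC#N)cc2-c2ccnc(-c3ccc(N(C)C)cc3)c2)c1` gives -10%, the lower of the two numbers, and its distance from compound 1 lies beyond the usual scatter. Compound 3 `Cc1cc(O)cc(-c2nn(CC#N)cc2-c2ccnc(-c3ccc(N(C)C)cc3)c2)c1` differs from compound 2 by hydrogen in place of methyl on an oxygen on an aromatic ring. Within the data shown here, no measured pair shows this change alone, so there is no step to lean on, and a step from compound 2 to compound 3 of about a number 5 percentage points higher from compound 2 to compound 3 (within the scatter) is expected, none beyond the scatter. Compound 3 is therefore estimated at -5%, between -22% and 14%.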

Compound 3, a percentage reported as activity, at one concentration (the size of the read-out at that concentration, not a potency): 4%
For compound 3 the middle estimate is 9 percentage points below the measured one, within the range that was stated.
By their numbers in this assay, from the lowest: compound 2; then compounds 1 and 3 (each within the scatter of the next).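

In this assay, among these compounds, the step of a number 14 percentage points higher from compound 2 to compound 3 (beyond the scatter) is the first reading of methoxy to hydroxy alone, and it shows a weaker effect at the concentration tested with hydroxy on the 3-hydroxy-5-methylphenyl group. With that hydroxy held fixed, dimethylamino in place of phenoxy gives no change at the digits printed from compound 1 to compound 3 (within the scatter) and so does not separate the two groups. Nothing shown here accounts for the methoxy to hydroxy step. Still open, on these data alone, is whether an amine or a carboxylic acid in place of the hydroxy would read closer to methoxy or to hydroxy. Also open, as far as these compounds go, is whether methoxy would give a similar step in a compound carrying phenoxy.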